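Carbonyl substituent change on the shared core: compound 4

The compounds below may be only part of what the source reports. "The series", "measured", "known", "first", "only" and "open" are said of these compounds alone.

The series holds three measured compounds on one core. Compound 1 `CCCOc1ccc2oc(/C=C/[S+](C)[O-])cc(=O)c2c1` carries propyl on an oxygen on an aromatic ring; in a functional assay on A549 cells (Homo sapiens) for cytotoxicity, with a stated time of 48 h (on this read-out higher numbers stand for weaker inhibition and lower numbers for stronger inhibition), compound 1 gives 1100 nM. Compound 2 `CCC(=O)Oc1ccc2oc(/C=C/[S+](C)[O-])cc(=O)c2c1` has propanoyl in that place and gives 2400 nM, a step of a 2.2-fold higher number from compound 1 to compound 2 (0.34 log units; beyond the scatter). Compound 3 `C[S+]([O-])/C=C/c1cc(=O)c2cc(OC(=O)C(C)(C)C)ccc2o1` carries (tert-butyl)carbonyl there and gives 1600 nM; from compound 1 the step is a 1.5-fold higher number from compound 1 to compound 3 (0.16 log units; within the scatter), and from compound 2 it is a 1.5-fold lower number from compound 2 to compound 3 (0.18 log units; within the scatter). Compound 3 thus stands second highest of the three numbers, with compound 1 nearest and compound 2 furthest, both within the scatter.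

Compound 4 `CC(C)CC(=O)Oc1ccc2oc(/C=C/[S+](C)[O-])cc(=O)c2c1` is not yet measured. It differs from compound 3 by isobutyl in place of tert-butyl on a carbonyl carbon. Going by the values given here, the one measured step that bears on this place is the change on the carbonyl carbon, ethyl to tert-butyl, which read a 1.5-fold lower number from compound 2 to compound 3 (0.18 log units; within the scatter) and stayed within the scatter. A further rearrangement of the same four carbons on that carbonyl carbon is therefore expected to give no step beyond the scatter, a 1.1-fold higher number from compound 3 to compound 4 (0.05 log units; within the scatter). Compound 4 is estimated at 1800 nM, with a range from 900 nM to 3600 nM.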

Compound 4, half-maximal inhibitory concentration: 2300 nM
Compound 4: middle estimate off by 1.3-fold (0.11 log units), on the low side; the measured number falls inside the stated range.
By their numbers in this assay, from the lowest: compounds 1, 3, 4 and 2 (each within the scatter of the next, the first and the last beyond it).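

In this assay the swap of tert-butyl for isobutyl on the carbonyl carbon, the same atoms joined differently, reads a 1.4-fold higher number from compound 3 to compound 4 (0.16 log units; within the scatter) and so stays within the scatter, which shows that this rearrangement of the four carbons does not separate the two compounds. Isopropyl in place of methyl on the saturated chain carbon bound to the carbonyl carbon reads a 1.0-fold lower number from compound 2 to compound 4 (0.02 log units; within the scatter) and adds a second step within the scatter, so compound 2, compound 3 and compound 4 cannot be told apart at this place. Against propyl on the oxygen, isobutylcarbonyl reads a 2.1-fold higher number from compound 1 to compound 4 (0.32 log units; beyond the scatter) and joins propanoyl in lying beyond the scatter, but compound 3 goes against any general rule for the carbonyl groups, since its step reads a 1.5-fold higher number from compound 1 to compound 3 (0.16 log units; within the scatter) and stays within the scatter.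

It remains open whether a much longer chain, a phenyl ring, an amine or a carboxylic acid on the carbonyl carbon would produce a step beyond the scatter among these carbonyl compounds. No measurement shown here accounts for the steps at this position.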